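Trimming a Methyl from Compound 2

The source may hold more compounds than are shown below. What is called first, only, known or untested is meant among the compounds shown, and "the series" means these compounds.

In a functional assay on L1210 cells (Mus musculus) for inhibition (on this read-out lower numbers stand for stronger inhibition and higher numbers for weaker inhibition), compound 2 `CCC(C)C1NC(=O)N(C2CCCC2)C1=O` reaches only the limit of the assay, > 200000 nM. Compound 1 `CC(C)C(NC(=O)NO)C(=O)NC1CCCCC1` likewise gives only a limit, > 100000 nM. Compound 3 `CCC(C)C(NC(=O)n1nnc2ccccc21)C(=O)NC(c1ccccc1)c1ccccc1` gives 17000 nM in this assay. Compound 2 thus stands at one of the two limits among the three values shown, namely (the limit of > 200000 nM in this assay, at which 1 of the 3 values shown sits); the other is the limit of > 100000 nM in this assay, at which 1 of the 3 values shown sits. Compound 4 `CC(C)C1NC(=O)N(C2CCCC2)C1=O` differs from compound 2 by hydrogen in place of methyl on a saturated chain carbon, two bonds along the chain from a saturated ring carbon. Within the data shown here, no measured pair shows such a step, so in this assay no change beyond the usual scatter is expected. Compound 4 is expected to give 200000 nM, between 50000 nM and 1000000 nM. The expected step is a number no higher from compound 2 to compound 4 (the limit leaves the size open).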

Compound 4, half-maximal inhibitory concentration: > 200000 nM
Compound 4 ended at the assay's limit; the forecaster's own chance of this, stated with the estimate: 85%; the middle value sits exactly at the limit.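

Compound 2 and compound 4 both sit at a limit in this assay, so no step can be read between them. The compounds shown leave open whether sec-butyl to isopropyl changes inhibition at all.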